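Urea series: aryl swap on the anilino nitrogen

The source may report more compounds than this note shows. Statements on the series, on what has been measured and on what is new or still open speak of the compounds shown alone.

Measured so far:
compound 1 `Cc1ccc(Nc2cc(NC(=O)Nc3c(Cl)cccc3Cl)ncn2)cc1C`, 84.3%
compound 2 `COc1cc(NC(=O)Nc2cc(Nc3cccc(C(C)(C)C)c3)ncn2)cc(OC)c1`, 48.7%

Both compounds were run in a functional assay on HCC827 cells (Homo sapiens) for inhibition, read by MTT assay, with a stated time of 48 h, tested at 10 uM; a lower number here means less inhibition, a higher number more inhibition at the concentration tested (going by the name of the read-out). Compound 1 gives 84.3% in this assay, the higher of the measured numbers; compound 2 gives 48.7%, and the gap between the values of compound 1 and compound 2 lies beyond the scatter. Compound 2 differs from compound 1 in more than one place, so no single-point step can be read from the pair.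

Compound 3 `O=C(Nc1cc(Nc2ccc(F)c(Cl)c2)ncn1)Nc1c(Cl)cccc1Cl` has not yet been measured in this assay. It departs from compound 1 at one place only: 3-chloro-4-fluorophenyl in place of 3,4-dimethylphenyl on a nitrogen on an aromatic ring. The shared core and the dichlorophenyl urea are kept.

Within the data shown here, no measured single-point step exists to calibrate this change. Since the group that leaves and the group that enters are of equal size and neither adds a donor or acceptor, the step is expected to be small, most likely within the scatter, with a slight downward lean allowed. The step from compound 1 to compound 3 is estimated at a number 8.3 percentage points lower from compound 1 to compound 3 (within the scatter). Compound 3 is therefore expected to give about 76% in this assay, in a range from 52% to 92%.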

Compound 3, a percentage reported as inhibition, at one concentration (the size of the read-out at that concentration, not a potency): 53.7%
Compound 3: middle estimate off by 22.3 percentage points, on the high side; the range from low to high includes it.
By their numbers in this assay, from the lowest: compounds 2 and 3 (each within the scatter of the next); then compound 1.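

In this assay, among these compounds, the group on a nitrogen on an aromatic ring turns out to be a sensitive place: with the shared core and the dichlorophenyl urea kept, 3-chloro-4-fluorophenyl in place of 3,4-dimethylphenyl gives a number 30.6 percentage points lower from compound 1 to compound 3 (beyond the scatter), the first single-point step. The two groups match in heavy-atom count and ring, and neither carries a hydrogen-bond donor, an acceptor or a net charge, so a change that leaves all of these counts the same can still produce a step beyond the scatter. Nothing at hand explains the size of this step.

The pair exchanges both ring substituents at once, so it cannot show whether the swap to chlorine or the swap to fluorine carries the step, and compound 2 differs from compound 1 and compound 3 in more than one place, so its steps cannot be read. On these data alone, how this position responds to a phenyl ring bearing a dimethylamino group or a carboxylic acid also remains open.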